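This account rests on a few compounds, and the source may have more. Where it says the series, first, only, none or still open, it means among the compounds named here.

In an ADME assay on NIH3T3 cells (Mus musculus) for cytotoxicity, read by MTT assay, with a stated time of 24 h (a higher number here means a weaker inhibitor, a lower number a stronger inhibitor), compound 1 `Cc1nnc(SCC(=O)N/N=c2/scc(-c3ccc([N+](=O)[O-])cc3)n2-c2ccccc2)s1` gives 177 ug/mL, the highest of the three numbers, though all three lie within the scatter of one another. Compound 2 `Cn1cnnc1SCC(=O)N/N=c1/scc(-c2ccc([N+](=O)[O-])cc2)n1-c1ccccc1` gives 133 ug/mL and compound 3 `Cn1nnnc1SCC(=O)N/N=c1/scc(-c2ccc([N+](=O)[O-])cc2)n1-c1ccccc1` gives 167 ug/mL; the steps of a 1.3-fold lower number from compound 1 to compound 2 (0.12 log units; within the scatter), a 1.1-fold lower number from compound 1 to compound 3 (0.03 log units; within the scatter) and a 1.3-fold higher number from compound 2 to compound 3 (0.10 log units; within the scatter) all change only the group on the sulfur. Compound 4 `Cc1nnc(SCC(=O)N/N=c2/scc(-c3ccc(Br)cc3)n2-c2ccccc2)s1` differs from compound 1 elsewhere: bromo in place of nitro on an aromatic carbon. Among the compounds with values here, no measured step touches that position, so nothing here reads on the change directly; the measured steps all stay within the scatter. For compound 4 a step of a 1.1-fold lower number from compound 1 to compound 4 (0.03 log units; within the scatter) is expected, no larger than the scatter, given that compound 1 gives 177 ug/mL. Compound 4 is therefore estimated at 165 ug/mL, between 75 ug/mL and 360 ug/mL.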

Compound 4, half-maximal inhibitory concentration: 55 ug/mL
The estimate for compound 4 lay 3.0-fold (0.48 log units) above the measured number, and the stated range ends above it.
By their numbers in this assay, from the lowest: compound 4; then compounds 2, 3 and 1 (each within the scatter of the next).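

Within the data shown here, the 4-nitrophenyl to 4-bromophenyl change gives the first step beyond the scatter in this assay: a 3.2-fold lower number from compound 1 to compound 4 (0.51 log units; beyond the scatter), whereas the changes of the group on the sulfur all stayed within it. For this pair, then, the number responds to the group on the aromatic carbon, though the step is modest. Nothing at hand bears on why bromo in place of nitro lowers the number.

On these data alone, whether the same step appears with the sulfur groups of compound 2 and compound 3 remains open. So does how an amine or a carboxylic acid at this position would read.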